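Propargyl to Allyl on a Series Stuck at the Limit

The source may hold more compounds than are shown below. What is called first, only, known or untested is meant among the compounds shown, and "the series" means these compounds.

Compound 3 `C#CCSc1nnc(CC)n1N1C(=O)c2ccccc2C1=O` was tested in a functional assay on HepG2 cells (Homo sapiens) for cytotoxicity, read by MTT assay, with a stated time of 48 h; on this read-out higher numbers stand for weaker inhibition and lower numbers for stronger inhibition. In this assay compound 3 reached only the limit > 200000 nM. Its two neighbours fare alike. Compound 1 `C#CCSc1nnc(C)n1N1C(=O)c2ccccc2C1=O` gives the limit > 200000 nM. Compound 2 `CSc1nnc(C)n1N1C(=O)c2ccccc2C1=O` gives the limit > 200000 nM. Because every reading sits at the limit of > 200000 nM in this assay, at which 3 of the 3 values shown sit, the step that the two limits leave unreadable from compound 1 to compound 2 and the step that the two limits leave unreadable from compound 1 to compound 3 have no readable size. Compound 4 `C=CCSc1nnc(CC)n1N1C(=O)c2ccccc2C1=O` differs from compound 3 by vinyl in place of ethynyl on a saturated chain carbon bound to a sulfur. Neither measured step offers a size to lean on, and no value moves off the limit. Compound 4 is therefore expected to show a step that the limit leaves unreadable from compound 3 to compound 4, landing at an estimated 250000 nM, with a range from 100000 nM to 600000 nM.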

Compound 4, half-maximal inhibitory concentration: > 200000 nM
Compound 4: only a limit was reported; the forecaster's own chance of this, stated with the estimate: 85%; the middle value is on the limit's open side.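

Compound 3 and compound 4 both sit at a limit of the assay, so the change from propargyl to allyl has no readable size: the limit of > 200000 nM in this assay, at which 4 of the 4 values shown sit.

The compounds shown leave open which change, if any, would bring a reading off this limit.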